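The source may report more compounds than this note shows. Statements on the series, on what has been measured and on what is new or still open speak of the compounds shown alone.

Working notes on the series in a functional assay on LNCaP cells (Homo sapiens) for antiproliferative activity, read by propidium iodide staining, with a stated time of 96 h; on this read-out lower numbers stand for stronger inhibition and higher numbers for weaker inhibition. Compound 1 `CC(O)(CSc1ccc(S(F)(F)(F)(F)F)cc1)C(=O)Nc1ccc(C#N)c(C(F)(F)F)c1` gives 16900 nM, and compound 2 `CC(O)(CSc1cc(C(F)(F)F)cc(C(F)(F)F)c1)C(=O)Nc1ccc(S(F)(F)(F)(F)F)cc1` gives 17600 nM. Compound 3 `CC(O)(COc1cccc(S(F)(F)(F)(F)F)c1)C(=O)Nc1cccc(S(F)(F)(F)(F)F)c1` gives 10900 nM, which lies within the scatter of both other values. Compound 4 `CC(O)(COc1cccc(C(F)(F)F)c1)C(=O)Nc1cccc(S(F)(F)(F)(F)F)c1` is still unmeasured. It differs from compound 3 by one change on an aromatic carbon: a group of 4 heavy atoms (1 carbon, 3 fluorine; no ring) in place of a group of 6 heavy atoms (5 fluorine, 1 sulfur; no ring), on an aromatic carbon. Within the data shown here, no measured pair differs in one place only, so the data give no direct size for such a change. No step beyond the scatter is expected in this assay, and the estimated 1.2-fold higher number from compound 3 to compound 4 (0.08 log units; within the scatter) stays within it. For compound 4 the expected value is 13000 nM, with an estimated range of 6000 nM to 28000 nM.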

Compound 4, half-maximal inhibitory concentration: 28800 nM
For compound 4 the middle estimate is 2.2-fold (0.35 log units) below the measured one, outside the stated range (above it).
By their numbers in this assay, from the lowest: compounds 3, 1, 2 and 4 (each within the scatter of the next, the first and the last beyond it).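

In this assay the step of a 2.6-fold higher number from compound 3 to compound 4 (0.42 log units; beyond the scatter) is the only one in the series that differs in one place, and it lies beyond the scatter. On this aromatic carbon, trifluoromethyl in place of the group of 5 fluorine and 1 sulfur gives weaker inhibition, so the position responds to this exchange, if modestly. Nothing available explains the step. On these data alone, whether the response follows heavy-atom count stays open, and a chlorine atom or a methoxy group on this carbon would bear on it. As far as these compounds go, whether the same exchange on the other aromatic ring gives a like step also stays open.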